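The source may hold more compounds than are shown below. What is called first, only, known or untested is meant among the compounds shown, and "the series" means these compounds.

- Compound 1 `CCC[C@@H](CCn1cncn1)c1ccc(C)cc1` gives 71.3 ug/mL 
- Compound 2 `Clc1ccc([C@H](CCn2cncn2)Cc2ccccc2)cc1` gives 25.7 ug/mL 

In an ADME assay on HEp-2 cells (Homo sapiens) for cytotoxicity, read by MTT assay, with a stated time of 3 days (on this read-out lower numbers stand for higher toxicity in this test and higher numbers for lower toxicity in this test), compound 2 holds the lower of the two numbers, a gap from compound 1 that lies beyond the scatter. Compound 3 `Cc1ccc([C@H](CCn2cncn2)Cc2ccccc2)cc1` changes compound 2 in one place: methyl in place of chloro on an aromatic carbon. This puts methyl in place of chloro on an aromatic carbon. Going by the values given here, no measured pair shows this swap on its own, so only a small rise is expected. The estimated step of a 1.2-fold higher number from compound 2 to compound 3 (0.10 log units; within the scatter) is expected to stay within the scatter. For compound 3 the expected value is 32 ug/mL, with an estimated range of 15 ug/mL to 65 ug/mL.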

Compound 3, half-maximal cytotoxic concentration: 152 ug/mL
Estimate against measurement, compound 3: 4.8-fold (0.68 log units) below, outside the stated range (above it).
By their numbers in this assay, from the lowest: compound 2; then compound 1; then compound 3.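

In this assay, methyl in place of chloro on an aromatic carbon gives a 5.9-fold higher number from compound 2 to compound 3 (0.77 log units; beyond the scatter), so this small swap moves the number clearly towards lower toxicity in this test. With the methyl kept, phenyl in place of ethyl on the saturated chain gives a 2.1-fold higher number from compound 1 to compound 3 (0.33 log units; beyond the scatter), so the chain also counts, though less. Nothing available here explains either step. Open, going by these compounds, is how a methoxy group or an amine on that same aromatic carbon would read, and whether the methyl-for-chloro step keeps its size with the chain of compound 1.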